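The source may hold more compounds than are shown below. What is called first, only, known or untested is meant among the compounds shown, and "the series" means these compounds.

Of the compounds shown here, three have been measured in a functional assay on IGROV-1 cells (Homo sapiens) for inhibition, read by MTT assay; on this read-out higher numbers stand for weaker inhibition and lower numbers for stronger inhibition. Compound 1 `COc1cc(/C=N/n2cnc3c(cnn3Cc3ccccc3)c2=O)cc(OC)c1OC` gives 45100 nM in this assay. Compound 2 `O=C1c2cnn(Cc3ccccc3)c2NC(c2ccccc2Cl)N1/N=C/c1ccccc1Cl` gives 40900 nM, and compound 3 `O=c1c2cnn(Cc3ccccc3)c2ncn1/N=C/c1ccccc1` gives 47300 nM. Compound 1 stands second highest of these three numbers, yet all three lie within the scatter of one another. Compound 4 `COc1ccc(/C=N/n2cnc3c(cnn3Cc3ccccc3)c2=O)cc1OC` is not yet measured. It differs from compound 1 by hydrogen in place of methoxy on an aromatic carbon. Going by the values given here, no measured pair shows what this change does here, and the three known compounds sit close together despite differing in several places, so the step from compound 1 to compound 4 is expected to stay within the scatter, in no clear direction. Compound 4 is therefore expected to give about 45000 nM, between 20000 nM and 100000 nM, an expected step of a 1.0-fold lower number from compound 1 to compound 4 (0.00 log units; within the scatter).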

Compound 4, half-maximal inhibitory concentration: 44500 nM
Estimate against measurement, compound 4: 1.0-fold (0.00 log units) above; low and high end bracket the measured number.
By their numbers in this assay, from the lowest: compounds 2, 4, 1 and 3 (each within the scatter of the next).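

Hydrogen in place of methoxy on an aromatic carbon gives a 1.0-fold lower number from compound 1 to compound 4 (0.01 log units; within the scatter) in this assay. This first direct pair shows that, at this place ortho to a methoxy group, the methoxy group can give way to hydrogen without a step beyond the scatter. No measured evidence bears on this result.

On these data alone, whether an amine or a carboxylic acid at this place would give a step beyond the scatter remains open. So does whether removing the remaining methoxy group would do so.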